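The source may report more compounds than this note shows. Statements on the series, on what has been measured and on what is new or still open speak of the compounds shown alone.

Three compounds have been measured in an ADME assay on SK-OV-3 cells (Homo sapiens) for cytotoxicity, read by sulforhodamine B assay, with a stated time of 48 h, tested at 10 uM; a lower number here means less inhibition, a higher number more inhibition at the concentration tested (going by the name of the read-out):

Compound 1 `CCCCCCCc1cn(C(c2ccccc2)c2cc3cc(Br)ccc3nc2OC)nn1` gives 10.5%.
Compound 2 `CCOC(=O)c1cn(C(c2ccccc2)c2cc3cc(Br)ccc3nc2OC)nn1` gives 2.01%.
Compound 3 `CCCc1cn(C(c2ccccc2)c2cc3cc(Br)ccc3nc2OC)nn1` gives 11.2%.

On these numbers compound 3 cannot be told apart from the other two: the step of a number 0.7 percentage points higher from compound 1 to compound 3 (within the scatter) and the step of a number 9.2 percentage points higher from compound 2 to compound 3 (within the scatter) both lie within the scatter, as does the step of a number 8.5 percentage points lower from compound 1 to compound 2 (within the scatter) between the other pair. The three values therefore sit together, and none of the three changes at the aromatic carbon of the five-membered ring has moved this assay beyond its noise.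

Compound 4 `COc1nc2ccc(Br)cc2cc1C(c1ccccc1)n1cc(-c2cccc(F)c2)nn1` is not yet measured. It differs from compound 3 by 3-fluorophenyl in place of propyl on an aromatic carbon. Among the compounds with values here, the steps that bear on this are those that also swapped the group on that aromatic carbon: heptyl to ethoxycarbonyl, and ethoxycarbonyl to propyl, both within the scatter. Within the data shown here, no measured step brings in a ring at this position, so the data give no direction for the new group. Compound 4 is therefore expected to stay close to compound 3, with a step of about a number 0.8 percentage points higher from compound 3 to compound 4 (within the scatter), which is no step beyond the scatter. The estimate for compound 4 in this assay is 12%, with a range from 0% to 30%.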

Compound 4, a percentage reported as inhibition, at one concentration (the size of the read-out at that concentration, not a potency): 12.7%
Compound 4: the middle estimate sits 0.7 percentage points below what was measured; the range from low to high includes it.
By their numbers in this assay, from the lowest: compounds 2, 1, 3 and 4 (each within the scatter of the next, the first and the last beyond it).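

Within the data shown here, with compound 4 a ring stands for the first time on the aromatic carbon of the five-membered aromatic ring, and in this assay the 3-fluorophenyl group cannot be told apart from the propyl chain it replaces, a number 1.5 percentage points higher from compound 3 to compound 4 (within the scatter), or from heptyl, a number 2.2 percentage points higher from compound 1 to compound 4 (within the scatter). The change from ethoxycarbonyl, a number 10.7 percentage points higher from compound 2 to compound 4 (beyond the scatter), is the only step among the compounds shown that passes the scatter, and it is modest, while compound 1 and compound 3 stay within the scatter of both compound 2 and compound 4, so the four values show no clear split between the groups at this carbon. Nothing at hand offers an explanation for this one separation.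

The compounds shown leave open whether the fluorine plays any part, which an unsubstituted phenyl at the same carbon would test, and whether a pyridine ring, an amine or a carboxylic acid there would move the number clearly beyond the scatter. They also leave open whether any change at this carbon can raise the inhibition far above the narrow band seen so far.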